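Chain amine variation on the stilbene ether series

The compounds below may be only part of what the source reports. "The series", "measured", "known", "first", "only" and "open" are said of these compounds alone.

Two members of this series have numbers in a functional assay on the whole organism with Mus musculus as the target, in the maximal electroshock model, at a dose of 50 mg/kg by the oral route; a lower number here means less inhibition, a higher number more inhibition at the dose given (going by the name of the read-out). Compound 1 `CN(C)CCCCOc1ccccc1/C=C/c1ccccc1Cl` gives 14.3%. Compound 2 `C(=C/c1ccccc1OCCCCN1CCCC1)\c1ccccc1` gives 42.9% and stands highest of the two, with compound 1 the nearest neighbour at a gap beyond the scatter; the two compounds differ in more than one place, so no single change can be tied to that gap.

Compound 3 `CN(C)CCN(C)CCCCOc1ccccc1/C=C/c1ccccc1` is not yet measured in this assay. It differs from compound 2 as follows: (2-(dimethylamino)ethyl)(methyl)amino in place of pyrrolidin-1-yl on a saturated chain carbon, four bonds along the chain from an oxygen on an aromatic ring. For the measured compounds named here, no step between measured compounds isolates an amine change, so there is little to go on beyond the values of compound 1 and compound 2. A small step is expected, downward at most, and not beyond the scatter, since the one other chain amine in the set, on compound 1, also carries a ring chlorine.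

Compound 3 is expected to give 35% in this assay, within 10% to 60%. The estimated step is a number 7.9 percentage points lower from compound 2 to compound 3 (within the scatter), expected to stay within the usual scatter.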

Compound 3, a percentage reported as inhibition, in the whole organism at one dose (the size of the read-out at that dose, not a potency): 0%
The estimate for compound 3 lay 35 percentage points above the measured number; the measured number lies below the stated range.
By their numbers in this assay, from the lowest: compound 3; then compound 1; then compound 2.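

For the compounds shown here, this is the first step that isolates the chain amine. In this assay, (2-(dimethylamino)ethyl)(methyl)amino in place of pyrrolidin-1-yl on a saturated chain carbon, four bonds along the chain from an oxygen on an aromatic ring, gives a number 42.9 percentage points lower from compound 2 to compound 3 (beyond the scatter), so the read-out at this dose depends strongly on the amine at this place, with the rest of the structure unchanged. No measurement on hand explains the size of this step.

On these data alone, whether the step follows from the loss of the ring, from the second nitrogen or from both stays open, and compound 1 cannot settle this, since it also carries a ring chlorine. As far as these compounds go, how a piperidine ring or a diethylamino group at this place would read in this assay also remains open.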